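The compounds below may be only part of what the source reports. "The series", "measured", "known", "first", "only" and "open" are said of these compounds alone.

Measured compounds, inhibition in a functional assay on A549 cells (Homo sapiens) for inhibition, read by MTT assay, with a stated time of 72 h; on this read-out higher numbers stand for weaker inhibition and lower numbers for stronger inhibition:
- Compound 1 `COc1cc(/C=C/C(=O)c2c(OC)cc(O)c(CC=C(C)C)c2O)ccc1O`: 11800 nM
- Compound 2 `COc1cc(O)c(CC=C(C)C)c(O)c1C(=O)/C=C/c1ccc([N+](=O)[O-])cc1`: 31200 nM

Going by the values given here, compound 2, at 31200 nM, holds the higher of the two numbers and so shows the weaker inhibition, with compound 1 as its only neighbour. Compound 3 `COc1cc(O)c(CC=C(C)C)c(O)c1C(=O)/C=C/c1cccc([N+](=O)[O-])c1` keeps the core of compound 2 and differs in one place: 3-nitrophenyl in place of 4-nitrophenyl on a double-bonded chain carbon bound to a double-bonded chain carbon. Among the compounds with values here, only one measured step is available, a 2.6-fold higher number from compound 1 to compound 2 (0.42 log units; beyond the scatter), a modest change in which 4-nitrophenyl replaced 4-hydroxy-3-methoxyphenyl. Within the data shown here, that step bears only loosely on this one, since no measured pair compares 3-nitrophenyl with 4-nitrophenyl. No shift beyond the scatter is therefore expected in this assay, and no direction can be favoured. The expected change is a 1.1-fold lower number from compound 2 to compound 3 (0.05 log units; within the scatter). For compound 3 the estimated value is 28000 nM, with an expected range of 14000 nM to 55000 nM.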

Compound 3, half-maximal inhibitory concentration: 15000 nM
Compound 3: middle estimate off by 1.9-fold (0.27 log units), on the high side, and the stated range covers the measured number.
By their numbers in this assay, from the lowest: compounds 1 and 3 (each within the scatter of the next); then compound 2.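

In this assay, 3-nitrophenyl in place of 4-nitrophenyl on a double-bonded chain carbon bound to a double-bonded chain carbon gives a 2.1-fold lower number from compound 2 to compound 3 (0.32 log units; beyond the scatter), so the read-out separates two groups with the same atoms joined differently. Against the 4-hydroxy-3-methoxyphenyl group, 3-nitrophenyl gives a 1.3-fold higher number from compound 1 to compound 3 (0.10 log units; within the scatter), which lies within the scatter, so a nitrophenyl group at this place does not by itself go with the higher number: of the three compounds, only compound 2 with 4-nitrophenyl stands apart. No measurement shown here explains the gap between 3-nitrophenyl and 4-nitrophenyl.

From the compounds shown here alone, whether a phenyl group carrying an amine or a carboxylic acid at this place would match compound 2 or compound 3 stays open. Also open, going by these compounds, is whether the gap between compound 2 and compound 3 holds on other cell lines.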